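A few compounds are considered here, and "the series" means these few. Any claim that something is new, unique, unknown or untested is made for them only; others in the source may bear on it.

Measured so far:
compound 1 `CC(Oc1ccc(-c2ccccc2)cc1)C(=O)Cn1nnc(-c2ccccc2)n1` — 5.3
compound 2 `CC(Oc1ccc(Oc2ccc(C(F)(F)F)cc2)cc1)C(=O)Cn1nnc(-c2ccc(Cl)cc2)n1` — 7

In a physicochemical assay for lipophilicity, read by HPLC, tested at 5 mM (on this read-out higher numbers stand for higher lipophilicity and lower numbers for lower lipophilicity), compound 2 gives 7, the highest of the two numbers; compound 1, the nearest, sits at 5.3, a gap beyond the scatter. Compound 3 `CC(Oc1ccc(-c2ccccc2)cc1)C(=O)Cn1nnc(-c2ccc(Cl)cc2)n1` is not yet measured. It differs from compound 2 by phenyl in place of 4-(trifluoromethyl)phenoxy on an aromatic carbon, with the rest of compound 2 kept. Within the data shown here, no step between two measured compounds covers this change, so its size is not known from the series. Since compound 1 carries a phenyl at the same place and gives 5.3, while compound 2 with the 4-(trifluoromethyl)phenoxy gives 7, a downward step from compound 2 to compound 3 is expected, estimated at a number 1.30 log units lower from compound 2 to compound 3 (beyond the scatter). Compound 3 is therefore expected at 5.7, with a range from 5.2 to 6.3 in this assay.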

Compound 3, partition coefficient: 6.1
Compound 3: middle estimate off by 0.40 log units, on the low side, within the range that was stated.
By their numbers in this assay, from the lowest: compound 1; then compound 3; then compound 2.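

In this assay, the change to phenyl in place of 4-(trifluoromethyl)phenoxy on this aromatic carbon, para to a large group, now has a size of its own, a number 0.90 log units lower from compound 2 to compound 3 (beyond the scatter), read with the rest of the molecule held fixed. The change of chloro in place of hydrogen on an aromatic carbon also has a size of its own, a number 0.80 log units higher from compound 1 to compound 3 (beyond the scatter), so each of the two single changes alone moves the number beyond the scatter. No measurement on hand accounts for either step.

As far as these compounds go, each step rests on a single pair of compounds, so it remains open whether the phenyl step would keep its size with hydrogen in place of the chloro, and whether the chloro step would keep its size with 4-(trifluoromethyl)phenoxy in place of the phenyl. From the compounds shown here alone, what an amine or a carboxylic acid on this aromatic carbon would do to the number also remains open.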